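Sulfinyl for Benzylsulfanyl on a Shared Bicyclic Core

The source may report more compounds than this note shows. Statements on the series, on what has been measured and on what is new or still open speak of the compounds shown alone.

Measured so far:
compound 1 `CCCCOc1nc(N)c2[nH]c(=O)n(Cc3ccccc3)c2n1` gives 0.001 uM
compound 2 `Nc1nc(SCc2ccccc2)nc2c1nc(O)n2Cc1ccccc1` gives 0.1 uM
compound 3 `COc1ccccc1Cn1c(O)nc2c(N)ncnc21` gives 10 uM

All three numbers come from a functional assay (spleen, spleen) for activation, with Mus musculus as the target; a higher number here means that more compound is needed for the effect, a lower number that less compound is needed. Compound 2 stands second highest of the three. Its nearest neighbour is compound 1, which gives a much lower number, and its furthest is compound 3, which gives a much higher one; both gaps lie well beyond the scatter. No pair among these three differs in one place only, so the numbers are taken as they stand and no single step is assigned to any one change.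

Compound 4 `CCCC[S+]([O-])c1nc(N)c2nc(O)n(Cc3ccccc3)c2n1` has not yet been measured in this assay. Compared with compound 2 it differs as follows: a group of 6 heavy atoms (4 carbon, 1 oxygen, 1 sulfur; no ring) in place of a group of 8 heavy atoms (7 carbon, 1 sulfur; one six-membered aromatic ring of carbon only), on an aromatic carbon

The entering group shares its chain length with the butoxy group of compound 1, and compound 1 is the strongest of the three in this assay. On that basis a modest move towards lower numbers is expected, not a jump to the level of compound 1. The step from compound 2 to compound 4 is estimated at a 3.3-fold lower number from compound 2 to compound 4 (0.52 log units; beyond the scatter), a little beyond the scatter. Compound 4 is expected to give about 0.03 uM, within a range of 0.003 uM to 0.3 uM.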

Compound 4, minimum effective concentration: 0.01 uM
The estimate for compound 4 lay 3.0-fold (0.48 log units) above the measured number; the measured number falls inside the stated range.
By their numbers in this assay, from the lowest: compound 1; then compound 4; then compound 2; then compound 3.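

Notes on the position between two ring nitrogen atoms: this is the first change in the series that can be read at one place, and in this assay it gives a 10-fold lower number from compound 2 to compound 4 (1.00 log units; beyond the scatter). Benzylsulfanyl, with its six-membered aromatic ring, is therefore not required at this aromatic carbon for the effect, since the entering group of 6 heavy atoms has no ring and compound 4 still gives a number beyond the scatter on the low side of compound 2. The counts of hydrogen-bond donors and acceptors and the absence of net charge stay the same across the change, and no measurement at hand bears on the reason for the step.

The step changes several things at once, including loss of the ring, the sulfur-bound oxygen and the butyl chain, so their separate shares cannot be read from these compounds. Butylsulfanyl at this carbon would separate the sulfur-bound oxygen from the loss of the ring, while a butylamino group or a longer chain such as hexylsulfinyl would show how far this position extends beyond sulfur-linked butyl.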